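A fluoro on the phenyl of compound 3

A few compounds are considered here, and "the series" means these few. Any claim that something is new, unique, unknown or untested is made for them only; others in the source may bear on it.

Of the compounds shown here, three sharing one core have been measured so far: compound 1 `CC(C)c1cccc(NC(=O)CCc2cccc3c2B(O)OC3)c1`, compound 2 `C#Cc1cccc(NC(=O)CCc2cccc3c2B(O)OC3)c1` and compound 3 `O=C(CCc1cccc2c1B(O)OC2)Nc1cccc(-c2ccccc2)c1`. They differ in a single group on an aromatic carbon, which is isopropyl, ethynyl or phenyl. In an ADME assay on WI-38 cells (Homo sapiens) for cytotoxicity, read by MTT assay, with a stated time of 72 h (a higher number here means a weaker inhibitor, a lower number a stronger inhibitor), compound 1 gives 22000 nM. Compound 3 gives 12000 nM. Compound 2 gives > 100000 nM, which is a limit of the assay and not a number. Going by the values given here, compound 3 therefore holds one of only two true numbers, and it cannot be separated from the other, since the step of a 1.8-fold lower number from compound 1 to compound 3 (0.26 log units; within the scatter) lies within the scatter.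

The next compound is compound 4 `O=C(CCc1cccc2c1B(O)OC2)Nc1cccc(-c2cccc(F)c2)c1`, with fluoro in place of hydrogen on an aromatic carbon, so that phenyl becomes 3-fluorophenyl. Among the compounds with values here, no measured step makes this change, so the evidence is indirect. Exchanges of the whole group gave an at least 4.5-fold higher number from compound 1 to compound 2 (0.65 log units; beyond the scatter) and an at least 8.3-fold lower number from compound 2 to compound 3 (0.92 log units; beyond the scatter), both beyond the scatter and both resting on the limit. Between true numbers, the exchange of isopropyl for phenyl gave only a 1.8-fold lower number from compound 1 to compound 3 (0.26 log units; within the scatter). A single added fluorine is therefore not expected to move the number beyond the scatter. The expected step is a 1.1-fold lower number from compound 3 to compound 4 (0.04 log units; within the scatter). The estimated value for compound 4 is 11000 nM, with an expected range of 5000 nM to 25000 nM.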

Compound 4, half-maximal inhibitory concentration: 37000 nM
The estimate for compound 4 lay 3.4-fold (0.53 log units) below the measured number; the whole stated range lies below it.
By their numbers in this assay, from the lowest: compounds 3, 1 and 4 (each within the scatter of the next, the first and the last beyond it). At a limit, above all of these: compound 2.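

In this assay, a single fluoro on the outer ring is enough to matter: a 3.1-fold higher number from compound 3 to compound 4 (0.49 log units; beyond the scatter) is a step beyond the scatter, and the 3-fluorophenyl group makes compound 4 a weaker inhibitor than the plain phenyl of compound 3, whereas the whole exchange of isopropyl for phenyl, a 1.8-fold lower number from compound 1 to compound 3 (0.26 log units; within the scatter), stayed within the scatter. The change is still small when set against isopropyl: a 1.7-fold higher number from compound 1 to compound 4 (0.23 log units; within the scatter) lies within the scatter, so compound 1 and compound 4 cannot be told apart. The step of an at least 2.7-fold lower number from compound 2 to compound 4 (0.43 log units; beyond the scatter) is also beyond the scatter, but compound 2 stands at a limit and not at a true number, so this step gives only a minimum size: the limit of > 100000 nM in this assay, at which 1 of the 4 values shown sits.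

With only hydrogen and fluoro shown on this ring, it remains open whether the shift is particular to fluoro or would also appear with chloro, methoxy or an amine on the same carbon. The compounds shown also offer no measured property that would explain the step from compound 3 to compound 4.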